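This account rests on a few compounds, and the source may have more. Where it says the series, first, only, none or still open, it means among the compounds named here.

Measured compounds in a functional assay on HeLa cells (Homo sapiens) for cytotoxicity, read by CCK-8 assay; a lower number here means a stronger inhibitor, a higher number a weaker inhibitor:
- compound 1 `Oc1cccc(-c2cc(-c3cccs3)cc(-c3cccc(O)c3)n2)c1`: 1690 nM
- compound 2 `Oc1cccc(-c2cc(-c3ccsc3)cc(-c3cccc(O)c3)n2)c1`: 16600 nM
- compound 3 `Oc1cccc(-c2cc(-c3ccco3)cc(-c3ccccc3O)n2)c1`: > 50000 nM

Compound 3 stands apart from the other two: its value is a limit of this assay and not a number, the same limit as the limit of > 50000 nM in this assay, at which 1 of the 3 values shown sits. Compound 1 and compound 2 are separated by the step of a 9.8-fold higher number from compound 1 to compound 2 (0.99 log units; beyond the scatter), which concerns the thiophene ring and not the hydroxyphenyl groups.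

Compound 4 `Oc1cccc(-c2cc(-c3ccco3)cc(-c3cccc(O)c3)n2)c1` differs from compound 3 as follows: 3-hydroxyphenyl in place of 2-hydroxyphenyl on an aromatic carbon. Within the data shown here, no measured step touches this change, since the only measured pair, compound 1 and compound 2, differs in the five-membered heteroaryl ring. Compound 1 does carry two 3-hydroxyphenyl groups, as compound 4 would, and gives a number rather than a limit in this assay. On that basis compound 4 is expected to return a number below the limit of compound 3, giving the step of an at least 8.3-fold lower number from compound 3 to compound 4 (0.92 log units; beyond the scatter), though with wide uncertainty. The estimate for compound 4 in this assay is 6000 nM, within 1200 nM to 40000 nM.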

Compound 4, half-maximal inhibitory concentration: 5990 nM
Compound 4: the middle estimate sits 1.0-fold (0.00 log units) above what was measured; the range from low to high includes it.
By their numbers in this assay, from the lowest: compound 1; then compound 4; then compound 2. At a limit, above all of these: compound 3.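

In this assay, 3-hydroxyphenyl in place of 2-hydroxyphenyl, on the aromatic carbon next to the ring nitrogen, gives an at least 8.3-fold lower number from compound 3 to compound 4 (0.92 log units; beyond the scatter), the first sign that this position responds to such a change. The value of compound 3 is a limit of the assay and not a number: the limit of > 50000 nM in this assay, at which 1 of the 4 values shown sits. With 3-hydroxyphenyl in this place, the five-membered ring can also be compared three ways, with furan-2-yl giving a 2.8-fold lower number from compound 2 to compound 4 (0.44 log units; beyond the scatter) and a 3.5-fold higher number from compound 1 to compound 4 (0.55 log units; beyond the scatter), so that the numbers rise from thiophen-2-yl through furan-2-yl to thiophen-3-yl.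

On these data alone, it remains open whether 2-hydroxyphenyl at this position would also give a limit alongside thiophen-2-yl or thiophen-3-yl. As far as these compounds go, it is equally open whether an amine or a methoxy group in place of the hydroxyl on this phenyl ring would still give a number in this assay.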